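Swapping a Para Methyl for Bromo on the Cinnamate Ester

The source may hold more compounds than are shown below. What is called first, only, known or untested is meant among the compounds shown, and "the series" means these compounds.

Measured so far:
- compound 1, `COc1cc(C2Oc3cc([C@H]4Oc5cc(O)cc(O)c5C(=O)[C@@H]4O)ccc3OC2COC(=O)c2cc(OC)c(OC)c(OC)c2)ccc1O`, giving 25700 nM in a functional assay on liver (Rattus norvegicus, strain Sprague-Dawley) for inhibition, with a stated time of 1 h; a lower number here means a stronger inhibitor, a higher number a weaker inhibitor
- compound 2, `COc1cc(C2Oc3cc([C@H]4Oc5cc(O)cc(O)c5C(=O)[C@@H]4O)ccc3OC2COC(=O)/C=C/c2ccc(C)cc2)ccc1O`, giving 14700 nM in this assay

Compound 2 has the lowest number of the two measured compounds, but its nearest neighbour, compound 1, lies within the scatter, so no order between them can be claimed. Compound 3, `COc1cc(C2Oc3cc([C@H]4Oc5cc(O)cc(O)c5C(=O)[C@@H]4O)ccc3OC2COC(=O)/C=C/c2ccc(Br)cc2)ccc1O`, differs from compound 2 only in one place: bromo in place of methyl on an aromatic carbon. Going by the values given here, the only measured step, a 1.7-fold lower number from compound 1 to compound 2 (0.24 log units; within the scatter), concerns a different part of the molecule, the whole acyl group on the carbonyl carbon, and stayed within the scatter; nothing measured speaks directly to a bromo for methyl exchange at this aromatic carbon. The expectation is therefore a step of a 1.2-fold lower number from compound 2 to compound 3 (0.09 log units; within the scatter), essentially no change beyond the scatter. Compound 3 is estimated at 12000 nM, with a range from 5000 nM to 30000 nM.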

Compound 3, half-maximal inhibitory concentration: 16300 nM
Estimate against measurement, compound 3: 1.4-fold (0.13 log units) below, within the range that was stated.
By their numbers in this assay, from the lowest: compounds 2, 3 and 1 (each within the scatter of the next).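

In this assay, bromo in place of methyl on this aromatic carbon gives a 1.1-fold higher number from compound 2 to compound 3 (0.04 log units; within the scatter) and so leaves no readable change: at this position the two groups cannot be told apart. The wider exchange on the carbonyl carbon gives a 1.6-fold lower number from compound 1 to compound 3 (0.20 log units; within the scatter) in the same way, so the 2-(4-bromophenyl)ethenyl group cannot be separated from the 3,4,5-trimethoxyphenyl group, just as the 2-(4-methylphenyl)ethenyl group could not. Nothing available explains why the number holds steady across these exchanges.

Still open, on these data alone, is whether a different kind of group on this aromatic carbon, such as an amine or a carboxylic acid, would move the number beyond the scatter. Also open, as far as these compounds go, is whether a longer chain between the carbonyl carbon and the aromatic ring would do so.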